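Extending the allyl arm of a tetrahydropyran scaffold

This account rests on a few compounds, and the source may have more. Where it says the series, first, only, none or still open, it means among the compounds named here.

Compound 1 `C=CC[C@H]1C[C@@H]([C@@H](O)c2ccccc2)CO[C@@H]1c1ccccc1`: 25400 nM
Compound 2 `COc1ccc(/C=C/C[C@H]2C[C@@H]([C@@H](OC(C)=O)c3ccc(OC)c(OC)c3)CO[C@@H]2c2ccc(OC)c(OC)c2)cc1OC`: > 100000 nM

Among the compounds with values here, in a functional assay on HeLa cells (Homo sapiens) for cytotoxicity, read by WST assay, with a stated time of 48 h (a lower number here means a stronger inhibitor, a higher number a weaker inhibitor), compound 1 gives 25400 nM, the only plain number among the two values shown. Compound 2 returns only a limit of the assay, > 100000 nM. Within the data shown here, this is the limit of > 100000 nM in this assay, at which 1 of the 2 values shown sits, and compound 2 differs from compound 1 in several places at once, so no single step between the two measured compounds can be read.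

Compound 3 `O[C@@H](c1ccccc1)[C@H]1CO[C@H](c2ccccc2)[C@@H](C/C=C/c2ccccc2F)C1` is not yet measured. It differs from compound 1 in one place: 2-(2-fluorophenyl)ethenyl in place of vinyl on a saturated chain carbon bound to a saturated ring carbon. Among the measured compounds shown here, with no measured step to lean on, the change is expected to move this assay by a small amount, if at all beyond the usual scatter, and the direction is uncertain. For compound 3 the estimate is 15000 nM, within 4000 nM to 60000 nM. That estimate amounts to an expected step of a 1.7-fold lower number from compound 1 to compound 3 (0.23 log units; within the scatter).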

Compound 3, half-maximal inhibitory concentration: 9730 nM
For compound 3 the middle estimate is 1.5-fold (0.19 log units) above the measured one; low and high end bracket the measured number.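

In this assay, the saturated chain carbon bound to a saturated ring carbon accepts a larger arm: 2-(2-fluorophenyl)ethenyl in place of vinyl gives a 2.6-fold lower number from compound 1 to compound 3 (0.42 log units; beyond the scatter). Within the data shown here, this is the first step that can be read at this place, as compound 2 differs from compound 1 in several places at once, and it shows that the added aromatic ring comes with a modest gain rather than a loss. Nothing among the data shown accounts for that gain.

The compounds shown leave open whether the fluorine contributes anything, or whether an unsubstituted 2-phenylethenyl arm would serve equally well. They also leave open how this place would respond to a different kind of group, such as an amine, a carboxylic acid or a longer saturated chain.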